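Heptyl in Place of Biphenylmethyl on the Spirohydantoin Nitrogen

This account rests on a few compounds, and the source may have more. Where it says the series, first, only, none or still open, it means among the compounds named here.

Compound 1 `CSc1ccc(N2C(=O)NC3(CCN(C(=O)c4cc(C(F)(F)F)cc(C(F)(F)F)c4)CC3)C2=O)cc1`: in an assay on CHO cells for binding affinity to Substance-P receptor (Homo sapiens) (a higher number here means a weaker inhibitor, a lower number a stronger inhibitor), compound 1 gives 132 nM
Compound 2 `O=C(c1cc(C(F)(F)F)cc(C(F)(F)F)c1)N1CCC2(CC1)NC(=O)N(Cc1cccc(-c3ccccc3)c1)C2=O`: in this assay compound 2 gives 138 nM

Two compounds share the spiro core carrying the bis(trifluoromethyl)benzoyl piperidine and differ only in what sits on the ring nitrogen of the hydantoin. Compound 2 has the higher of the two numbers, but its nearest neighbour, compound 1, lies so close that the two values fall within the scatter of the measurement, so nothing can be said about an order between them.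

Compound 3 `CCCCCCCCN1C(=O)NC2(CCN(C(=O)c3cc(C(F)(F)F)cc(C(F)(F)F)c3)CC2)C1=O` has not been measured. The change from compound 2 is heptyl in place of 3-phenylphenyl on a saturated chain carbon bound to an amide-type nitrogen in a ring. Within the data shown here, with both aromatic rings of that substituent gone and a plain chain in their place, no measured pair offers a guide to the size of such a step. The account expects the binding to weaken by a moderate amount, a 3.6-fold higher number from compound 2 to compound 3 (0.56 log units; beyond the scatter), beyond the scatter but not by a large margin. On that basis compound 3 is estimated at 500 nM in this assay, with a plausible range from 120 nM to 2500 nM.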

Compound 3, inhibition constant: 2040 nM
For compound 3 the middle estimate is 4.1-fold (0.61 log units) below the measured one, and the stated range covers the measured number.
By their numbers in this assay, from the lowest: compounds 1 and 2 (each within the scatter of the next); then compound 3.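

The two earlier compounds carry quite different aromatic groups on this position and stand within the scatter of each other, which made the position look tolerant, but compound 3 shows that this tolerance has limits. In this assay, among these compounds, the heptyl in place of 3-phenylphenyl on a saturated chain carbon bound to an amide-type nitrogen in a ring gives a 15-fold higher number from compound 2 to compound 3 (1.17 log units; beyond the scatter) and, read from the other neighbour, octyl in place of 4-(methylsulfanyl)phenyl on an amide-type nitrogen in a ring gives a 15-fold higher number from compound 1 to compound 3 (1.19 log units; beyond the scatter) so both large steps end at the one compound of the three with no aromatic ring in this substituent. Nothing shown here explains why the plain chain costs so much binding.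

Three compounds cannot separate the loss of the aromatic rings from the presence of the flexible chain, nor show how binding varies with chain length. A benzyl group, a shorter or longer chain, or a chain ending in an amine or a phenyl ring would each help to show what this position requires.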